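The source may hold more compounds than are shown below. What is called first, only, known or untested is meant among the compounds shown, and "the series" means these compounds.

Measured so far in a functional assay on DU-145 cells (Homo sapiens) for cytotoxicity, read by trypan blue exclusion, with a stated time of 96 h; on this read-out higher numbers stand for weaker inhibition and lower numbers for stronger inhibition:
compound 1 `COc1cc(OC)c(/C=C/S(=O)(=O)Cc2ccc(OC)c([N+](=O)[O-])c2)c(OC)c1` gives 2500 nM
compound 2 `COc1cc(OC)c(/C=C/[S+]([O-])Cc2ccc(OC)c(N)c2)c(OC)c1` gives 40 nM
compound 3 `COC(=O)CCNc1cc(CS(=O)(=O)/C=C/c2c(OC)cc(OC)cc2OC)ccc1OC` gives 1500 nM

Compound 3 holds the second highest of these three numbers. Its value lies within the scatter of the value of compound 1, while compound 2 shows a much lower number.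

Compound 4 `COC(=O)C(F)(F)Nc1cc(CS(=O)(=O)/C=C/c2c(OC)cc(OC)cc2OC)ccc1OC` has not yet been measured. In it, difluoro(methoxycarbonyl)methyl stands in place of 2-(methoxycarbonyl)ethyl on a nitrogen on an aromatic ring (difluoro(methoxycarbonyl)methyl in place of 2-(methoxycarbonyl)ethyl on a nitrogen on an aromatic ring) while the rest of compound 3 is kept.

Going by the values given here, one measured step bears on this change (a 1.7-fold lower number from compound 1 to compound 3 (0.22 log units; within the scatter)) and it lies within the scatter. Among the compounds with values here, that step swapped nitro for the amino chain of compound 3, so it shows one replacement at this place and nothing about fluorine, since no fluorinated compound has been measured. Compound 2 differs from compound 3 in more than one place and offers no clean comparison.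

On this thin evidence, no step beyond the scatter is expected in this assay and the range has to stay wide. The expected step is a 1.2-fold lower number from compound 3 to compound 4 (0.06 log units; within the scatter) as a small one. The estimate for compound 4 is 1300 nM with 400 nM to 4000 nM as its expected range.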

Compound 4, half-maximal inhibitory concentration: 250 nM
For compound 4 the middle estimate is 5.2-fold (0.72 log units) above the measured one, and the stated range ends above it.
By their numbers in this assay, from the lowest: compound 2; then compound 4; then compounds 3 and 1 (each within the scatter of the next).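

In this assay, the group on the nitrogen on the aromatic ring turns out to matter: difluoro(methoxycarbonyl)methyl in place of 2-(methoxycarbonyl)ethyl gives a 6.0-fold lower number from compound 3 to compound 4 (0.78 log units; beyond the scatter). The earlier change at this place, a 1.7-fold lower number from compound 1 to compound 3 (0.22 log units; within the scatter), stayed within the scatter, so compounds 1 and 3 alone gave no sign that this position could move the number beyond it; the new (difluoro(methoxycarbonyl)methyl)amino group does so against nitro as well, with a 10-fold lower number from compound 1 to compound 4 (1.00 log units; beyond the scatter). No measurement is at hand that explains why this exchange lowers the number.

The compounds shown leave open whether the lower number belongs to the two fluorine atoms themselves or to the change of chain that came with them, which a methoxycarbonylmethyl group without fluorine would separate. They also leave open whether the methyl ester is needed at this place, a question that a carboxylic acid or a primary amide on the same difluoromethyl chain would address.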